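Dichloroacetanilides on lung cancer cells: fluoro to bromo

This account rests on a few compounds, and the source may have more. Where it says the series, first, only, none or still open, it means among the compounds named here.

Measured compounds:
compound 1 `O=C(Nc1cccc(F)c1)C(Cl)Cl` — "not determined" (no result reported)
compound 2 `N#Cc1cccc(NC(=O)C(Cl)Cl)c1` — 66500 nM
compound 3 `O=C(Nc1ccc(F)cc1)C(Cl)Cl` — 68400 nM

Three anilides of the same dichloroacetyl core were examined in a functional assay on A549 cells (Homo sapiens) for antiproliferative activity, read by MTT assay, with a stated time of 72 h; a higher number here means a weaker inhibitor, a lower number a stronger inhibitor. For compound 1 this assay reports "not determined" (no result reported). Compound 2 gives 66500 nM and compound 3 gives 68400 nM; these two numbers lie within the scatter of each other, so neither can be called the weaker or the stronger inhibitor, and compound 3 simply stands level with compound 2 at the upper end of the two values that are known.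

The next compound, compound 4 `O=C(Nc1ccc(Br)cc1)C(Cl)Cl`, differs from compound 3 in one place: bromo in place of fluoro on an aromatic carbon. Going by the values given here, no pair of measured compounds separated by this same exchange is available, so the size of the step cannot be read from the data. Halogen swaps of this kind on an anilide ring are, in the experience of such series, usually modest, and the expectation is a small step in this assay toward a lower number, of a size that may not exceed the scatter; the estimated step is a 1.7-fold lower number from compound 3 to compound 4 (0.23 log units; within the scatter). Compound 4 is therefore expected to give about 40000 nM, with a likely range from 12000 nM to 120000 nM.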

Compound 4, half-maximal inhibitory concentration: 13700 nM
Beside the measured number, compound 4's estimate is 2.9-fold (0.47 log units) above it, within the range that was stated.
By their numbers in this assay, from the lowest: compound 4; then compounds 2 and 3 (each within the scatter of the next).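

Going by these compounds alone, exchanging fluoro for bromo on the aromatic carbon para to a group of 6 heavy atoms gives, in this assay, a 5.0-fold lower number from compound 3 to compound 4 (0.70 log units; beyond the scatter), the first step in this set that can be read and one that lies beyond the scatter. It shows that this place on the ring is not indifferent to which halogen it carries, even though the exchange swaps one heavy atom for one heavy atom and leaves the counts of rings, hydrogen-bond donors, hydrogen-bond acceptors and net charge unchanged. No measurement at hand bears on why the number falls with this exchange.

With only fluoro and bromo compared at this place, the compounds shown leave open whether chloro or iodo would extend the same step, and so whether the two halogens mark the ends of a trend or merely one isolated pair. They also leave open how an amine, a methoxy group or a carboxylic acid at this same carbon would compare with bromo on the shared core.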